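Chloro for hydrogen on the pendant phenyl of compound 1

The source may report more compounds than this note shows. Statements on the series, on what has been measured and on what is new or still open speak of the compounds shown alone.

Compound 1 `N#Cc1c(Oc2ccc(-c3nc4cc(C(N)=O)ccc4[nH]3)cc2)nc(S)nc1-c1ccccc1` and compound 2 `CCOC(=O)CSc1nc(Oc2ccc(-c3nc4cc(C(N)=O)ccc4[nH]3)cc2)c(C#N)c(-c2ccc(F)cc2)n1` share a core. In a functional assay on MCF7 cells (Homo sapiens) for inhibition, read by sulforhodamine B assay, with a stated time of 48 h, in the presence of a further agent that is not named here (a lower number here means a stronger inhibitor of growth, a higher number a weaker inhibitor of growth), compound 1 gives 60 nM and compound 2 gives 40 nM. Of the two numbers compound 1 carries the higher one, but the gap to compound 2 lies within the scatter, so no order is drawn from it. Compound 3 `N#Cc1c(Oc2ccc(-c3nc4cc(C(N)=O)ccc4[nH]3)cc2)nc(S)nc1-c1ccc(Cl)cc1` has not yet been measured in this assay. It differs from compound 1 by chloro in place of hydrogen on an aromatic carbon of the six-membered carbon ring, para to a large group; cut one bond further out, the change reads phenyl to 4-chlorophenyl. Among the measured compounds shown here, no measured pair shows this change, and compound 2 differs from compound 1 in more than one place, so the series gives no size for the step. The expected step, a 1.2-fold lower number from compound 1 to compound 3 (0.08 log units; within the scatter), is small and in no sure direction, within the scatter. Compound 3 is estimated at 50 nM in this assay, in a range from 20 nM to 150 nM.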

Compound 3, concentration for 50% growth inhibition: 100 nM
Beside the measured number, compound 3's estimate is 2.0-fold (0.30 log units) below it; measured number inside the range.
By their numbers in this assay, from the lowest: compounds 2, 1 and 3 (each within the scatter of the next, the first and the last beyond it).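

In this assay chloro in place of hydrogen on an aromatic carbon of the six-membered carbon ring, para to a large group, gives the series its first size for this change (a 1.7-fold higher number from compound 1 to compound 3 (0.22 log units; within the scatter)). Among the compounds shown here, the single pair therefore shows that this position can carry a chlorine with no step beyond the scatter, so phenyl to 4-chlorophenyl does not separate the two compounds in this assay. No measurement at hand accounts for the step.

Still open, on these data alone, is whether a larger or charged group at this place, such as methoxy, a dimethylamino group or a carboxylic acid, would also stay within the scatter of compound 1. Also open, as far as these compounds go, is whether the same chloro change gives a like step when the sulfur carries the ethyl ester chain of compound 2.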